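Anilino to 4-methoxyphenyl on the carbonyl: series notes

The source may hold more compounds than are shown below. What is called first, only, known or untested is meant among the compounds shown, and "the series" means these compounds.

Measured so far in a functional assay on MCF7 cells (Homo sapiens) for antiproliferative activity, read by sulforhodamine B assay, with a stated time of 48 h, tested at 50 uM; on this read-out lower numbers stand for less inhibition and higher numbers for more inhibition at the one concentration tested (going by the name of the read-out):
- compound 1 `CC1=CC[C@H](C(C)C)c2cc(C)c(OC(=O)Nc3ccccc3)cc21`: 75.1%
- compound 2 `COc1cccc(C(=O)Oc2cc3c(C)ccc(C(C)C)c3cc2C)c1`: 31.8%

Compound 1 stands highest of the two numbers in this assay; compound 2 lies well below it, a gap beyond the usual scatter of repeated runs. Within the data shown here, no step between these two is counted, since they differ in more than one place, so their two values are simply taken as they stand.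

The next compound on the core of compound 1 is compound 3 `COc1ccc(C(=O)Oc2cc3c(cc2C)[C@@H](C(C)C)CC=C3C)cc1`, not yet measured in this assay. It differs from compound 1 in one place: 4-methoxyphenyl in place of anilino on a carbonyl carbon. The carbamate of compound 1 thus becomes an ester in compound 3, with a methoxy group carried on the new ring.

Only one ester has been measured, compound 2, whose value in this assay sits far under compound 1, and it differs from compound 3 in the core as well. The expected step from compound 1 to compound 3 is therefore a fall, and not a small one: a number 30.1 percentage points lower from compound 1 to compound 3 (beyond the scatter) is the estimate of that step. Compound 3 is estimated at 45% in this assay, with a range from 20% to 70%.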

Compound 3, a percentage reported as inhibition, at one concentration (the size of the read-out at that concentration, not a potency): 80.1%
Compound 3: middle estimate off by 35.1 percentage points, on the low side; measured number outside the range, above it.
By their numbers in this assay, from the lowest: compound 2; then compounds 1 and 3 (each within the scatter of the next).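

In this assay, 4-methoxyphenyl in place of anilino on a carbonyl carbon gives a number 5 percentage points higher from compound 1 to compound 3 (within the scatter), so on the core of compound 1 this read-out does not separate the carbamate from the ester. The change removes the hydrogen-bond donor counted on anilino and brings in the hydrogen-bond acceptor counted on 4-methoxyphenyl, and this pair shows that the donor is not required at this place for inhibition at the one concentration tested. No measurement to hand accounts for the two groups reading alike.

Among these compounds, compound 2 differs from each of the other two compounds in more than one place, so no step to it can be read, and the pair of compound 1 and compound 3 remains the only evidence on this change. Still open, on these data alone, is how far this place accepts other groups on the carbonyl carbon, such as an unsubstituted phenyl ring, a longer alkyl chain, a ring bearing a dimethylamino group or a carboxylic acid, and a single-concentration read-out gives no potency for any of them.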